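The compounds below may be only part of what the source reports. "The series", "measured", "known", "first", "only" and "open" are said of these compounds alone.

Compound 2 `C#CCOc1cccc(/C=C/C(=O)Nc2cc(C(=O)c3cc(OC)c(OC)c(OC)c3)ccc2OC)c1` and compound 1 `COc1ccc(C(=O)c2cc(OC)c(OC)c(OC)c2)cc1NC(=O)/C=C/c1ccc(OC)c(OC)c1` share one core and differ only in the ring carried on the double-bonded chain. In a functional assay on HeLa cells (Homo sapiens) for cytotoxicity, read by MTT assay, with a stated time of 72 h (a higher number here means a weaker inhibitor, a lower number a stronger inhibitor), compound 1 gives 7800 nM, and compound 2 gives 14000 nM; the step of a 1.8-fold higher number from compound 1 to compound 2 (0.25 log units; within the scatter) shows that the two numbers sit within the scatter of each other, so on the numbers shown compound 2 is not separated from compound 1.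

Compound 3 `COc1ccc(C(=O)c2cc(OC)c(OC)c(OC)c2)cc1NC(=O)/C=C/c1ccc([N+](=O)[O-])cc1` has not yet been measured. Its change from compound 2 is 4-nitrophenyl in place of 3-(propargyloxy)phenyl on a double-bonded chain carbon bound to a double-bonded chain carbon. Within the data shown here, the only measured step that bears on it is the same kind of change, a swap of the ring on that chain carbon, and that step, a 1.8-fold higher number from compound 1 to compound 2 (0.25 log units; within the scatter), stayed within the scatter. From this one example the expected step of a 1.4-fold lower number from compound 2 to compound 3 (0.15 log units; within the scatter) is none beyond the scatter. Compound 3 is therefore estimated at 10000 nM in this assay, with a range from 3500 nM to 30000 nM.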

Compound 3, half-maximal inhibitory concentration: 8500 nM
Estimate against measurement, compound 3: 1.2-fold (0.07 log units) above, and the stated range covers the measured number.
By their numbers in this assay, from the lowest: compounds 1, 3 and 2 (each within the scatter of the next).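

Two more swaps of the ring on this chain carbon, a 1.6-fold lower number from compound 2 to compound 3 (0.22 log units; within the scatter) and a 1.1-fold higher number from compound 1 to compound 3 (0.04 log units; within the scatter), both stay within the scatter in this assay, so 3,4-dimethoxyphenyl, 3-(propargyloxy)phenyl and 4-nitrophenyl cannot be told apart at this position. The nitro group is a different kind of group from the ether-linked groups on the other two rings, yet even this change does not separate compound 3 from compound 1 or compound 2. No measurement at hand says why the three numbers lie so close.

As far as these compounds go, all three compounds carry a substituted phenyl ring here, so it remains open whether a ring bearing an amine or a carboxylic acid would move the number beyond the scatter. The same question remains for a plain phenyl ring or a longer chain at this place.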